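Swapping the aryl group on the hydrazone of compound 2

The source may hold more compounds than are shown below. What is called first, only, known or untested is meant among the compounds shown, and "the series" means these compounds.

Measured compounds:
- compound 1 `C#CCSc1nc(N/N=C/c2ccc(N(C)C)cc2)c2nnn(Cc3ccccc3)c2n1`: in a functional assay on MGC-803 cells (Homo sapiens) for antiproliferative activity, read by MTT assay, with a stated time of 72 h (on this read-out lower numbers stand for stronger inhibition and higher numbers for weaker inhibition), compound 1 gives 7620 nM
- compound 2 `CCCSc1nc(N/N=C(\C)c2ccc(OC)cc2)c2nnn(Cc3ccccc3)c2n1`: in this assay compound 2 gives 44300 nM
- compound 3 `C#CCSc1nc(N/N=C/c2c(O)ccc3ccccc23)c2nnn(Cc3ccccc3)c2n1`: in this assay compound 3 gives 10500 nM

Among these three, compound 2 stands at the highest number, and its gaps to compound 3 and to compound 1 both lie beyond the scatter, so it is the weakest of the set. Among the measured compounds shown here, compound 2 also differs from the other two in more than one place, with a longer saturated chain on the sulfur and a methyl on the carbon with a double bond to nitrogen, so no single step ties it to them.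

Compound 4 `CCCSc1nc(N/N=C(\C)c2ccccc2O)c2nnn(Cc3ccccc3)c2n1` keeps everything of compound 2 except the aryl group: 2-hydroxyphenyl in place of 4-methoxyphenyl on a carbon with a double bond to nitrogen. For the measured compounds named here, the only measured step that changes an aryl group in this position is the one from compound 1 to compound 3, a 1.4-fold higher number from compound 1 to compound 3 (0.14 log units; within the scatter), and there a hydroxyl-bearing aryl replaced a different one without moving the number beyond the scatter. That step does not involve a methoxy group, so it bears on the present change only loosely. On that basis the expected step in this assay is small, with no confident direction: a 1.3-fold lower number from compound 2 to compound 4 (0.10 log units; within the scatter). Compound 4 is therefore estimated at 35000 nM, within a range from 12000 nM to 100000 nM.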

Compound 4, half-maximal inhibitory concentration: 2310 nM
The estimate for compound 4 lay 15-fold (1.18 log units) above the measured number; the whole stated range lies above it.
By their numbers in this assay, from the lowest: compound 4; then compounds 1 and 3 (each within the scatter of the next); then compound 2.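

In this assay, the step of a 19-fold lower number from compound 2 to compound 4 (1.28 log units; beyond the scatter) shows that the aryl group on the carbon with a double bond to nitrogen can by itself move the number far beyond the scatter, with the rest of the molecule unchanged. Among the compounds shown here, the only earlier aryl change at this place, a 1.4-fold higher number from compound 1 to compound 3 (0.14 log units; within the scatter), stayed within the scatter, so that step alone had given no sign that this place could matter so much, and the new step shows that the choice of aryl group here is not a neutral one. The swap removes a methoxy group and brings in a hydroxyl, which adds a hydrogen-bond donor, but nothing measured here explains why the number fell so far.

From the compounds shown here alone, what remains open is which part of the swap carries the step, since the oxygen group changes in kind and in its number in the ring name at once; 4-hydroxyphenyl and 2-methoxyphenyl would each change only one of these. Also open, going by these compounds, is whether a related group such as 2-aminophenyl would behave like 2-hydroxyphenyl, and whether the same swap would give a step of this size with a different chain on the sulfur.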